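A few compounds are considered here, and "the series" means these few. Any claim that something is new, unique, unknown or untested is made for them only; others in the source may bear on it.

In a functional assay on Jurkat cells (Homo sapiens) (a lower number here means a stronger inhibitor, a higher number a weaker inhibitor), compound 1 `CC(C)[C@H](NC(=O)COc1cccc2ccccc12)C(=O)N[C@@H](CC(=O)O)C(=O)COc1ccccc1C(F)(F)F` reads > 100000 nM as a limit, not a number. Compound 2 `CC(C)[C@H](NC(=O)COc1cccc2ccccc12)C(=O)N[C@@H](CC(=O)O)C(=O)COc1ccc(C#N)cc1` reads > 100000 nM, also a limit. Among the compounds with values here, the only measured step is a step that the two limits leave unreadable from compound 1 to compound 2 and the series so far shows the limit of > 100000 nM in this assay, at which 2 of the 2 values shown sit, with no readable potency. Within the data shown here, compound 3 `CC(C)[C@H](NC(=O)COc1cccc2ccccc12)C(=O)N[C@@H](CC(=O)O)C(=O)COc1ccc(C(N)=O)cc1` differs from compound 2 by carbamoyl in place of cyano on an aromatic carbon and no measured step gives a size or direction for this change. With nothing readable to go on, the expected a number no higher from compound 2 to compound 3 (the limit leaves the size open) is no change beyond the scatter. For compound 3 the estimate is 100000 nM with a range of 30000 nM to 300000 nM and a further limit is the likely report.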

Compound 3, half-maximal inhibitory concentration: > 100000 nM
Compound 3 ended at the assay's limit; the forecaster's own chance of this, stated with the estimate: 85%; the middle value lies on the limit itself.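

No step can be read among compound 1, compound 2 and compound 3, since each value is a limit and not a number: the limit of > 100000 nM in this assay, at which 3 of the 3 values shown sit.

The compounds shown leave open whether changing this substituted phenyl group can give a readable potency in this assay.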